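The compounds below may be only part of what the source reports. "The series", "measured", "known", "first", "only" and "open" are said of these compounds alone.

Of the compounds shown here, two sharing one core have so far been measured in a functional assay on SJ-G2 cells (Homo sapiens) for inhibition, read by MTT assay, with a stated time of 72 h; on this read-out higher numbers stand for weaker inhibition of growth and lower numbers for stronger inhibition of growth. Compound 1, `COc1ccc(CNC(=O)/C(C#N)=C/c2ccc(Cl)o2)cc1`, gives 13000 nM in this assay. Compound 2, `COc1ccc(CNC(=O)/C(C#N)=C/c2ccc3ccccc3c2)cc1`, gives 40000 nM in this assay, which is the higher of the two numbers; its gap to compound 1 lies beyond the usual scatter, so on this read-out compound 2 is the weaker grower-inhibitor of the pair.

Compound 3, `N#C/C(=C\c1ccc2ccccc2c1)C(=O)NCc1ccc(Cl)c(Cl)c1`, has not yet been measured. It keeps the core of compound 2 and differs from it in one place: 3,4-dichlorophenyl in place of 4-methoxyphenyl on a saturated chain carbon bound to an amide-type nitrogen. Among the measured compounds shown here, no measured pair in this set shows that exchange, so its effect is not anchored by any number here, and the only footing is the value of compound 2 itself. The expected step is a 1.6-fold lower number from compound 2 to compound 3 (0.20 log units; within the scatter), modest enough that it could still fall within the scatter. Compound 3 is therefore estimated to give 25000 nM in this assay. For compound 3 the expected range runs from 8000 nM to 80000 nM.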

Compound 3, concentration for 50% growth inhibition: 49000 nM
Beside the measured number, compound 3's estimate is 2.0-fold (0.29 log units) below it, within the range that was stated.
By their numbers in this assay, from the lowest: compound 1; then compounds 2 and 3 (each within the scatter of the next).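

In this assay, placing 3,4-dichlorophenyl where 4-methoxyphenyl stood, on a saturated chain carbon bound to an amide-type nitrogen, gives a 1.2-fold higher number from compound 2 to compound 3 (0.09 log units; within the scatter), so this assay does not tell the two compounds apart. Among the compounds shown here, this is the first reading at this position, and it shows that a swap from a ring bearing one oxygen-containing group to a ring bearing two chlorines, with the same count of heavy atoms and one hydrogen-bond acceptor fewer, leaves no difference that can be separated from ordinary assay variation on the core of compound 2. No supporting measurement is available here to explain this outcome, and a single pair cannot show how the position behaves in general.

The compounds shown leave open whether the same exchange would also read as flat on the core of compound 1, whose value is the only one that stands apart in this small set. They also leave open what happens at this position with a group of a different kind, such as an amine, a carboxylic acid or a longer chain carrying the aromatic ring.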